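A few compounds are considered here, and "the series" means these few. Any claim that something is new, unique, unknown or untested is made for them only; others in the source may bear on it.

Compound 1 `COc1cc2c(Oc3ccc(NC(=O)c4nn(-c5ccc(Br)cc5)c(=O)c5ccccc45)cc3F)ccnc2cc1OCCCN1CCCC1` and compound 2 `COc1cc2c(Oc3ccc(NC(=O)c4nn(-c5ccc([N+](=O)[O-])cc5)c(=O)c5ccccc45)cc3F)ccnc2cc1OCCCN1CCCC1` share one core and differ at a single spot, (nitro in place of bromo on an aromatic carbon). In a functional assay on HT-29 cells (Homo sapiens) for cytotoxicity, read by MTT assay, with a stated time of 72 h (a higher number here means a weaker inhibitor, a lower number a stronger inhibitor), compound 1 gives 670 nM, while compound 2 gives 1760 nM. That single change made a 2.6-fold higher number from compound 1 to compound 2 (0.42 log units; beyond the scatter). Compound 3 `COc1cc2c(Oc3ccc(NC(=O)c4nn(-c5ccc(Br)cc5)c(=O)c5ccccc45)cc3F)ccnc2cc1OCCCN1CCCCC1` rests on a slightly different core; the difference between the two cores is piperidin-1-yl in place of pyrrolidin-1-yl on a saturated chain carbon, three bonds along the chain from an oxygen on an aromatic ring. Measured in this assay, compound 3 gives 770 nM. The core swap itself made a 1.1-fold higher number from compound 1 to compound 3 (0.06 log units; within the scatter), so the two cores behave much alike here. Compound 4 `COc1cc2c(Oc3ccc(NC(=O)c4nn(-c5ccc([N+](=O)[O-])cc5)c(=O)c5ccccc45)cc3F)ccnc2cc1OCCCN1CCCCC1` has not yet been measured. It arises from compound 3 by nitro in place of bromo on an aromatic carbon, the same change that turned compound 1 into compound 2, at the same place on the ring. Because the core swap gave only a 1.1-fold higher number from compound 1 to compound 3 (0.06 log units; within the scatter), the change is expected to act on the second core as it did on the first. The step expected from the first to the second is therefore a 2.6-fold higher number from compound 3 to compound 4 (0.41 log units; beyond the scatter). On that basis compound 4 is estimated to give 2000 nM in this assay, with a likely range from 1100 nM to 3700 nM.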

Compound 4, half-maximal inhibitory concentration: 2170 nM
For compound 4 the middle estimate is 1.1-fold (0.04 log units) below the measured one; the measured number falls inside the stated range.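

In this assay, nitro in place of bromo gave a 2.8-fold higher number from compound 3 to compound 4 (0.45 log units; beyond the scatter), and this step agrees with the one seen on the core of compound 1: the same change on two cores in this assay, a 2.6-fold higher number (0.42 log units; beyond the scatter) from compound 1 to compound 2 and a 2.8-fold higher number (0.45 log units; beyond the scatter) from compound 3 to compound 4, 1.1-fold (0.03 log units) apart, within the scatter of two such steps. Read the other way, piperidin-1-yl in place of pyrrolidin-1-yl gave a 1.2-fold higher number from compound 2 to compound 4 (0.09 log units; within the scatter), and that swap likewise behaves alike with nitro and with bromo on the ring: the same change on two cores in this assay, a 1.1-fold higher number (0.06 log units; within the scatter) from compound 1 to compound 3 and a 1.2-fold higher number (0.09 log units; within the scatter) from compound 2 to compound 4, 1.1-fold (0.03 log units) apart, within the scatter of two such steps. Across these four compounds, the two changes therefore add up simply, so the step from bromo to nitro carries from one core to the other, but this does not show that it would carry to any further core or into another assay, nor does it explain why nitro gives the higher number.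

The compounds shown leave open how a chloro, a methoxy or an amino group would compare in the place of bromo and nitro. They also leave open whether the same agreement would hold with morpholin-4-yl in place of piperidin-1-yl, or with a longer chain.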